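The source may report more compounds than this note shows. Statements on the series, on what has been measured and on what is new or still open speak of the compounds shown alone.

Of the compounds shown here, three built on one shared core have been measured in an assay on isolated protein for inhibition of alpha-ketoglutarate-dependent dioxygenase alkB homolog 3 (Homo sapiens), read by polymerase chain reaction, with a stated time of 1 h; on this read-out higher numbers stand for weaker inhibition and lower numbers for stronger inhibition. Compound 1 `COc1ccc(Cc2c(C)[nH]n(-c3nc4ccccc4[nH]3)c2=O)cc1` gives 630 nM, the lowest of the three numbers. Compound 3 `Cc1[nH]n(-c2nc3ccccc3[nH]2)c(=O)c1Cc1ccc(-c2ccccc2)cc1` gives 720 nM; the step of a 1.1-fold higher number from compound 1 to compound 3 (0.06 log units; within the scatter) shows that exchanging the group on the outer ring of the benzyl arm leaves the read-out essentially unchanged. Compound 2 `Cc1cc(O)n(-c2nc3ccccc3[nH]2)n1`, which has no benzyl arm at all, gives 3600 nM, a number that stands apart from compound 1 by more than the usual scatter.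

Compound 4 `Cc1[nH]n(-c2nc3ccccc3[nH]2)c(=O)c1Cc1ccc(Cl)cc1Cl` has not yet been measured. It differs from compound 1 in one place: 2,4-dichlorophenyl in place of 4-methoxyphenyl on a saturated chain carbon bound to an aromatic carbon. Among the compounds with values here, the only measured step that bears on this change is a 1.1-fold higher number from compound 1 to compound 3 (0.06 log units; within the scatter), which lies within the scatter, and it suggests that altering the substituents on that outer ring does little while the arm itself remains. The expected step is therefore small, a 1.1-fold higher number from compound 1 to compound 4 (0.05 log units; within the scatter), in no clear direction. For compound 4 in this assay the estimate is 700 nM, with a range from 250 nM to 2000 nM.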

Compound 4, half-maximal inhibitory concentration: > 10000 nM
Compound 4: no number, only a limit; the forecaster's own chance of this, stated with the estimate: 5%; middle value at least 14-fold (1.15 log units) away from the limit.
By their numbers in this assay, from the lowest: compounds 1 and 3 (each within the scatter of the next); then compound 2. At a limit, above all of these: compound 4.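

Compound 4 has no exact number in this assay, only a limit: the limit of > 10000 nM in this assay, at which 1 of the 4 values shown sits. Even so, the step is clear: replacing 4-methoxyphenyl with 2,4-dichlorophenyl gives an at least 15-fold higher number from compound 1 to compound 4 (1.20 log units; beyond the scatter), whereas the change from methoxy to phenyl gave only a 1.1-fold higher number from compound 1 to compound 3 (0.06 log units; within the scatter). The outer ring of the benzyl arm is therefore not as free to change as compounds 1 and 3 alone suggested, since one exchange there barely moves the read-out and another moves it by a large amount.

This single step removes the methoxy group and adds two chlorine atoms at once, so the compounds shown cannot say which of these changes matters. Going by these compounds, it also remains open how a ring with a single chlorine, or one carrying a hydroxyl group or an amine, would behave at this place.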